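Swapping methyl for chloro on the aryl ring: a second test

A few compounds are considered here, and "the series" means these few. Any claim that something is new, unique, unknown or untested is made for them only; others in the source may bear on it.

Of the compounds shown here, three that share a core have been measured in an assay on isolated protein for inhibition of Thymidylate synthase (Homo sapiens); a lower number here means a stronger inhibitor, a higher number a weaker inhibitor. Compound 1, `CC(=O)N1CCN(C(=O)Cn2c(-c3ccc(C)cc3)csc2=N)CC1`, gives 3650 nM. Compound 3, `CC(=O)N1CCN(C(=O)Cn2c(-c3ccc(Cl)cc3)csc2=N)CC1`, gives 11300 nM. It differs from compound 1 in one place: chloro in place of methyl on an aromatic carbon. Between them the step is a 3.1-fold higher number from compound 1 to compound 3 (0.49 log units; beyond the scatter). Compound 2, `Cc1ccc(-c2csc(=N)n2CC(=O)N2CCOCC2)cc1`, gives 4060 nM; the difference between the core of compound 1 and the core of compound 2 is not broken down here, and the values of compound 1 and compound 2 lie within the usual scatter of each other.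

Compound 4, `N=c1scc(-c2ccc(Cl)cc2)n1CC(=O)N1CCOCC1`, has not yet been measured. It stands to compound 2 as compound 3 stands to compound 1: chloro in place of methyl on an aromatic carbon. The place of the change is the same in both pairs, so this is the same change seen a second time. Within the data shown here, the only guide is the single earlier step, so the expectation for compound 4 is that it weakens the inhibition by a similar amount, because a 3.1-fold higher number from compound 1 to compound 3 (0.49 log units; beyond the scatter) was the outcome when this change was made on compound 1. Compound 4 is therefore estimated at 12500 nM, expected to lie between 6000 nM and 26000 nM, which corresponds to an expected step of a 3.1-fold higher number from compound 2 to compound 4 (0.49 log units; beyond the scatter).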

Compound 4, inhibition constant: 3730 nM
Estimate against measurement, compound 4: 3.4-fold (0.53 log units) above, and the stated range ends above it.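

In this assay, the swap from 4-methylphenyl to 4-chlorophenyl did not repeat its earlier effect, as the new step, a 1.1-fold lower number from compound 2 to compound 4 (0.04 log units; within the scatter), makes clear when set beside the first: the same change on two cores in this assay, a 3.1-fold higher number (0.49 log units; beyond the scatter) from compound 1 to compound 3 and a 1.1-fold lower number (0.04 log units; within the scatter) from compound 2 to compound 4, 3.4-fold (0.53 log units) apart, beyond the scatter of two such steps

Within these two pairs, then, the outcome of this change depends on the core that carries it: the weakening seen on the core of compound 1 does not appear on the core of compound 2. What two pairs cannot show is why the cores part ways, which feature of the cores matters, or which result would be the more typical on a further core in this series.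

The compounds shown carry only methyl or chloro at this place on the aromatic ring. As far as these compounds go, it remains open how a fluoro, a methoxy, an amine or a carboxylic acid placed there would behave, and whether any of these would also give different results on the two cores.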